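A few compounds are considered here, and "the series" means these few. Any claim that something is new, unique, unknown or untested is made for them only; others in the source may bear on it.

Of the compounds shown here, three from one series have been tested in a functional assay on HeLa cells (Homo sapiens) for cytotoxicity, read by MTT assay, with a stated time of 72 h; on this read-out lower numbers stand for stronger inhibition and higher numbers for weaker inhibition. Compound 1 `CC1=C[C@H](OC(=O)c2ccc(O)cc2)[C@@H]2[C@](C)(CC[C@@]2(O)C(C)C)CC1=O` is the only one to give a measured number: in this assay compound 1 gives 26100 nM. Compound 2 `C/C=C(\C)C(=O)O[C@H]1C[C@@]2(C)O[C@H]2[C@@H](OC(C)=O)[C@@]2(C)CC[C@@](O)(C(C)C)[C@H]12` reaches only a limit in this assay, reported as > 100000 nM. Compound 3 `C=C1C[C@H](OC(=O)c2ccc(O)cc2)[C@@H]2[C@](C)(CC[C@@]2(O)C(C)C)C[C@@H]1O` likewise stops at a limit in this assay, reported as > 100000 nM. Compound 1 therefore stands alone with a number, while the other two sit at the limit of > 100000 nM in this assay, at which 2 of the 3 values shown sit.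

Compound 4 `COc1ccc(C(=O)O[C@H]2C=C(C)C(=O)C[C@@]3(C)CC[C@@](O)(C(C)C)[C@H]23)cc1` has not yet been tested in this assay. It differs from compound 1 in one place: methyl in place of hydrogen on an oxygen on an aromatic ring. Going by the values given here, no pair of measured compounds differs by a single change, so no measured step gives a scale for how much this kind of change can shift the read-out. With so small a change, the expected step in this assay is a 1.3-fold higher number from compound 1 to compound 4 (0.13 log units; within the scatter), not clearly beyond the usual scatter, leaning if anything toward slightly weaker inhibition. Compound 4 is therefore expected to give about 35000 nM in this assay, with a range from 12000 nM to 100000 nM.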

Compound 4, half-maximal inhibitory concentration: 29700 nM
Compound 4: middle estimate off by 1.2-fold (0.07 log units), on the high side; the measured number falls inside the stated range.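

Going by these compounds alone, replacing 4-hydroxyphenyl with 4-methoxyphenyl gives a 1.1-fold higher number from compound 1 to compound 4 (0.06 log units; within the scatter) in this assay, and this is the first single change that can be read as a step. At this place, on an oxygen on an aromatic ring, a methyl can therefore stand in for the hydrogen without moving the read-out beyond the usual scatter, so the free hydroxy is not needed for compound 1 to give a number rather than a limit. Nothing measured here explains why the read-out holds steady under this change.

The compounds shown leave open whether a longer chain on this oxygen, such as ethyl or benzyl, would leave the read-out just as unmoved. They also leave open what an amine or a carboxylic acid in place of the hydroxy would do in this assay at this same position.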